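The source may hold more compounds than are shown below. What is called first, only, known or untested is meant among the compounds shown, and "the series" means these compounds.

Measured so far:
compound 1, `CS(=O)(=O)Oc1ccc2c3c(c(=O)oc2c1)CCCCCC3`: 24500 nM
compound 2, `CCCS(=O)(=O)Oc1ccc2c3c(c(=O)oc2c1)CCCCCC3`: 9200 nM
compound 3, `O=c1oc2cc(OS(=O)(=O)c3ccccc3)ccc2c2c1CCCCCC2`: a limit of the assay, > 100000 nM

In an ADME assay on RAW264.7 cells (Mus musculus) for cytotoxicity, read by MTT assay, with a stated time of 24 h (a lower number here means a stronger inhibitor, a higher number a weaker inhibitor), compound 1 gives 24500 nM, the highest of the two numbers shown. Its nearest neighbour is compound 2, which sits a step away of a 2.7-fold lower number from compound 1 to compound 2 (0.43 log units; beyond the scatter). The third value shown is a limit and not a number: compound 3 reaches the limit of > 100000 nM in this assay, at which 1 of the 3 values shown sits, in this assay.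

Compound 4, `O=c1oc2cc(OS(=O)(=O)c3ccc(C(F)(F)F)cc3)ccc2c2c1CCCCCC2`, is not yet measured. It differs from compound 1 in one place, (4-(trifluoromethyl)phenyl in place of methyl on a sulfonyl sulfur). For the measured compounds named here, the measured step that bears most directly on this change is the one from compound 1 to compound 3, which replaces the same methyl with a phenyl on the same sulfonyl sulfur and gives an at least 4.0-fold higher number from compound 1 to compound 3 (0.61 log units; beyond the scatter). The step of an at least 10-fold higher number from compound 2 to compound 3 (1.03 log units; beyond the scatter) points the same way, from a larger starting number. Both aromatic replacements on the sulfonyl sulfur therefore move this assay towards the limit, and compound 4 carries an aromatic group of the same kind.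

Compound 4 is thus expected to give a higher number than compound 1, a step of about a 4.1-fold higher number from compound 1 to compound 4 (0.61 log units; beyond the scatter). The estimate for compound 4 in this assay is 100000 nM, with a range from 40000 nM to 300000 nM, and a sizeable chance that only a limit is reported.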

Compound 4, half-maximal inhibitory concentration: > 100000 nM
Compound 4 gave a limit, no number; the forecaster's own chance of this, stated with the estimate: 60%; the middle value sits exactly at the limit.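

In this assay, putting a trifluoromethyl group on the phenyl ring does not bring the sulfonyl series back below the limit, and the 4-(trifluoromethyl)phenyl group gives an at least 4.0-fold higher number from compound 1 to compound 4 (0.61 log units; beyond the scatter), as well as an at least 10-fold higher number from compound 2 to compound 4 (1.03 log units; beyond the scatter). Among the compounds shown, the split on this sulfonyl sulfur now holds for two aromatic groups as well as two chains, with no compound against it: compound 1 and compound 2, with methyl and propyl, give numbers, while compound 3 and compound 4, with phenyl and 4-(trifluoromethyl)phenyl, give only limits: the limit of > 100000 nM in this assay, at which 2 of the 4 values shown sit. The step from compound 3 to compound 4 cannot be read, as both values are limits, so nothing can be said about what the trifluoromethyl group adds to the phenyl ring on its own.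

From the compounds shown here alone, what remains open is whether the split depends on the aromatic ring itself, which a benzyl group or a pyridine ring on the sulfonyl sulfur would test. Going by these compounds, it is equally open whether a longer chain such as hexyl would continue the step seen from methyl to propyl, or whether an amine on the phenyl ring would bring a measurable number into this assay.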